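Non-aromatic five-membered ring replaces the 3-methyl-1,2-oxazol-5-yl group

This account rests on a few compounds, and the source may have more. Where it says the series, first, only, none or still open, it means among the compounds named here.

Among the measured compounds shown here, compound 2 `CC1=CC(=O)N(Nc2nc(-c3cccs3)ncc2-c2cc(C)no2)C1=O` gives 300 nM in a functional assay on Jurkat cells for inhibition of nuclear factor NF-kappa-B complex (Homo sapiens) (a lower number here means a stronger inhibitor, a higher number a weaker inhibitor), the lowest of the two numbers so far. Compound 1 `CCOC(=O)c1cnc(-c2ccccc2)nc1N(C)N1C(=O)C=C(C)C1=O` gives 2000 nM in this assay, a gap beyond the scatter. Compound 3 `CC1=CC(=O)N(Nc2nc(-c3cccs3)ncc2C2=NCCO2)C1=O` carries a group of 5 heavy atoms (3 carbon, 1 nitrogen, 1 oxygen; one five-membered non-aromatic ring with 2 hetero atoms) in place of a group of 6 heavy atoms (4 carbon, 1 nitrogen, 1 oxygen; one five-membered aromatic ring with 2 hetero atoms), on an aromatic carbon, para to a thiophen-2-yl group. For the measured compounds named here, no measured pair shows this change. Both groups count 2 hydrogen-bond acceptors and no donors, so only a modest move toward a weaker inhibitor is expected, with the expected step of a 2.0-fold higher number from compound 2 to compound 3 (0.30 log units; within the scatter) near the edge of the scatter. Compound 3 is estimated at 600 nM, range 150 nM to 2500 nM.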

Compound 3, half-maximal inhibitory concentration: 200 nM
Estimate against measurement, compound 3: 3.0-fold (0.48 log units) above; the range from low to high includes it.
By their numbers in this assay, from the lowest: compounds 3 and 2 (each within the scatter of the next); then compound 1.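

In this assay, putting the non-aromatic five-membered ring in place of the 3-methyl-1,2-oxazol-5-yl group leaves compound 2 and compound 3 within the scatter (a 1.5-fold lower number from compound 2 to compound 3 (0.18 log units; within the scatter)). At this position, para to a thiophen-2-yl group, an aromatic ring is therefore not required to hold this level, at least for these two groups. No measurement shown bears on why the two groups read alike.

On these data alone, whether a ring is needed here at all remains open. A carboxylic acid, a primary amide or a plain methyl group at this position, on the core of compound 2, would test that.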